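Compound 4: a chloro analogue of compound 2

A few compounds are considered here, and "the series" means these few. Any claim that something is new, unique, unknown or untested is made for them only; others in the source may bear on it.

Measured in an ADME assay on CCRF-CEM cells (Homo sapiens) for cytotoxicity, with a stated time of 5 days (a lower number here means a stronger inhibitor, a higher number a weaker inhibitor), each value being a limit and not a number:
Compound 1 `C=CCNc1nc(N)nc2c1ncn2[C@H]1C[C@H](N=[N+]=[N-])[C@@H](CO)O1`: > 100000 nM
Compound 2 `COc1nc(F)nc2c1ncn2[C@H]1C[C@H](N=[N+]=[N-])[C@@H](CO)O1`: > 100000 nM
Compound 3 `COc1nc(OC)c2ncn([C@H]3C[C@H](N=[N+]=[N-])[C@@H](CO)O3)c2n1`: > 100000 nM

Compound 2 offers no exact starting point, since its > 100000 nM is a limit. It shares that position with the other two compounds, as the series shows (the limit of > 100000 nM in this assay, at which 3 of the 3 values shown sit). Compound 4 `[N-]=[N+]=N[C@H]1C[C@H](n2cnc3c(Cl)nc(F)nc32)O[C@@H]1CO` has chloro in place of methoxy on an aromatic carbon. Within the data shown here, the one measured step that bears on this change is a step that the two limits leave unreadable from compound 2 to compound 3, in which methoxy takes the place of fluoro on an aromatic carbon. That step also swaps methoxy and fluoro rather than chloro, and it has no readable size. The data therefore give no direction for the new change, and no step beyond the scatter is expected in this assay. The expected change is an at least 1.1-fold lower number from compound 2 to compound 4 (0.04 log units; that floor lies within the scatter). Compound 4 is estimated at 90000 nM, with an expected range from 30000 nM to 100000 nM.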

Compound 4, half-maximal inhibitory concentration: 13300 nM
Estimate against measurement, compound 4: 6.8-fold (0.83 log units) above; the whole stated range lies above it.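

In this assay, compound 2 gives > 100000 nM, which is a limit and not a number. Chloro in place of methoxy on an aromatic carbon, next to the ring nitrogen, gives an at least 7.5-fold lower number from compound 2 to compound 4 (0.87 log units; beyond the scatter), which shows that a change at this position can move the compound beyond the scatter and off the limit. Compound 4 is the only compound shown with an exact value, while the other three remain at the limit: the limit of > 100000 nM in this assay, at which 3 of the 4 values shown sit.

As far as these compounds go, the steps among compounds at the limit cannot be read, and the true size of the step to compound 4 remains unknown. The compounds shown leave open how a bromo, methyl or amine group at this position would compare with chloro, and whether the result holds without the fluoro group.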